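Compound 3 to compound 4: amino in place of hydroxy

The source may report more compounds than this note shows. Statements on the series, on what has been measured and on what is new or still open speak of the compounds shown alone.

In a functional assay on Vero cells (Chlorocebus sabaeus) for inhibition (a lower number here means a stronger inhibitor, a higher number a weaker inhibitor), compound 3 `OC[C@H]1O[C@@H](n2cnc3c(O)ncnc32)CS1` gives > 100000 nM, which is a limit and not a number. Compound 2 `CNc1ncnc2c1ncn2[C@H]1CS[C@@H](CO)O1` gives > 100000 nM, also a limit. Going by the values given here, compound 1 `Nc1nc(F)nc2c1ncn2[C@H]1CS[C@@H](CO)O1` gives 5600 nM, the only number so far. Compound 4 `Nc1ncnc2c1ncn2[C@H]1CS[C@@H](CO)O1` follows from compound 3 by amino in place of hydroxy on an aromatic carbon, with amino in place of hydroxy on an aromatic carbon. Among the compounds with values here, the one measured step is a step that the two limits leave unreadable from compound 2 to compound 3, so it offers no size to carry over. Of the measured compounds, only compound 1 at 5600 nM carries amino on that carbon, so stronger inhibition in this assay is expected. The expected step is an at least 5.0-fold lower number from compound 3 to compound 4 (0.69 log units; beyond the scatter), though its true size stays uncertain. Compound 4 is estimated at 20000 nM, with an expected range of 4000 nM to 100000 nM.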

Compound 4, half-maximal inhibitory concentration: > 100000 nM
Compound 4: a limit, no number (the forecaster's own chance of this, stated with the estimate: 35%); middle value at least 5.0-fold (0.69 log units) from the limit.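

In this assay compound 4 gives > 100000 nM, which is a limit of the assay and not a number. The steps among compound 2, compound 3 and compound 4 cannot be read, and all three stop at the same ceiling: the limit of > 100000 nM in this assay, at which 3 of the 4 values shown sit.

Amino on this carbon therefore does not by itself give a number, and the fluoro of compound 1 matters, with hydrogen in place of fluoro on an aromatic carbon as the one readable step, an at least 17-fold higher number from compound 1 to compound 4 (1.25 log units; beyond the scatter).

Going by these compounds, whether chloro or methoxy in place of that fluoro would keep a number in this assay stays open. Also open, on these data alone, is whether fluoro would give a number alongside methylamino or hydroxy in place of the amino.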